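A few compounds are considered here, and "the series" means these few. Any claim that something is new, unique, unknown or untested is made for them only; others in the source may bear on it.

Measured so far in a physicochemical assay for lipophilicity, read by HPLC, at pH 7.5; on this read-out higher numbers stand for higher lipophilicity and lower numbers for lower lipophilicity:
compound 1 `CC[C@@H](Nc1c(C#N)c(-c2ccc(Br)cc2)nc2cnccc12)C(=O)O` reads 1.6
compound 2 `CC[C@@H](Nc1c(C#N)c(-c2ccc(-c3cccc(Cl)c3F)cc2)nc2cnccc12)C(=O)O` reads 2.2

Among the measured compounds shown here, compound 1 holds the lower of the two numbers, and the single measured step (a number 0.60 log units higher from compound 1 to compound 2 (beyond the scatter)) lies beyond the scatter. Compound 3 `CC(Nc1c(C#N)c(-c2ccc(Br)cc2)nc2cnccc12)C(N)=O` keeps the shared core and the bromo group of compound 1 and differs in one place (1-carbamoylethyl in place of 1-carboxypropyl on a nitrogen on an aromatic ring): 1-carbamoylethyl in place of 1-carboxypropyl on a nitrogen on an aromatic ring. For the measured compounds named here, the measured step replaces bromo on an aromatic carbon, so no measured step touches this chain, and that modest step serves only as a rough gauge of size. A rise of similar or somewhat larger size is expected, with no direct support in the data. The expected change is a number 1.00 log units higher from compound 1 to compound 3 (beyond the scatter) as a rough figure. The estimate for compound 3 is 2.6 (expected range 2 to 3.2).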

Compound 3, distribution coefficient: 2.1
Compound 3: middle estimate off by 0.50 log units, on the high side; the measured number falls inside the stated range.
By their numbers in this assay, from the lowest: compound 1; then compounds 3 and 2 (each within the scatter of the next).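

In this assay, the chain on the nitrogen on an aromatic ring proves to be a second place where the read-out moves: 1-carbamoylethyl in place of 1-carboxypropyl gives a number 0.50 log units higher from compound 1 to compound 3 (beyond the scatter) with the shared core and the bromo group kept. This single change alters the chain end, the chain length and the defined stereocentre together, so the step cannot be assigned to any one of them. Nothing on hand accounts for the rise.

Open, going by these compounds, is which part of the change carries the step: a 1-carboxyethyl or a 1-carbamoylpropyl group on the same nitrogen would separate chain length from chain end. Also open, on these data alone, is whether the step holds with 3-chloro-2-fluorophenyl in place of bromo.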